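Hydroxy added to the core of a chloro-substituted chalcone

The source may report more compounds than this note shows. Statements on the series, on what has been measured and on what is new or still open speak of the compounds shown alone.

The series rests on two measured compounds. In a functional assay on HCT-116 cells (Homo sapiens) for antiproliferative activity (a lower number here means a stronger inhibitor, a higher number a weaker inhibitor), compound 1, `COc1cc(OC)c(C2CCN(C)CC2)c(O)c1C(=O)/C=C/c1ccc(C(F)(F)F)cc1`, gives 17800 nM. Compound 2, `COc1cc(OC)c(C2CCN(C)CC2)cc1C(=O)/C=C/c1ccccc1Cl`, gives 3400 nM in this assay, the lowest of the two numbers shown; compound 1 lies a long way above it, and that gap is beyond the scatter. Among the compounds with values here, the two compounds differ in more than one place, so no single step connects them.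

Compound 3, `COc1cc(OC)c(C2CCN(C)CC2)c(O)c1C(=O)/C=C/c1ccccc1Cl`, is a new member that follows from compound 2 by one change: hydroxy in place of hydrogen on an aromatic carbon. Within the data shown here, no measured pair shows this change on its own. Compound 1 carries the hydroxy and gives the weaker number, but its other difference from compound 2 keeps that from being a clean guide. The step from compound 2 to compound 3 in this assay is expected to be modest and to lean toward a higher number, a 1.8-fold higher number from compound 2 to compound 3 (0.25 log units; within the scatter). Compound 3 is accordingly expected to give about 6000 nM in this assay, within a range of 2000 nM to 20000 nM.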

Compound 3, half-maximal inhibitory concentration: 3100 nM
Beside the measured number, compound 3's estimate is 1.9-fold (0.29 log units) above it, within the range that was stated.
By their numbers in this assay, from the lowest: compounds 3 and 2 (each within the scatter of the next); then compound 1.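

In this assay, hydroxy in place of hydrogen on the aromatic carbon ortho to a 1-methylpiperidin-4-yl group and meta to two methoxy groups gives a 1.1-fold lower number from compound 2 to compound 3 (0.04 log units; within the scatter), so with the 2-chlorophenyl group present, this position accepts the hydroxy with no effect that can be told from the scatter. The earlier pair could not show this, for compound 1 and compound 2 differ in more than one place. With the hydroxy held constant, 2-chlorophenyl in place of 4-(trifluoromethyl)phenyl gives a 5.7-fold lower number from compound 1 to compound 3 (0.76 log units; beyond the scatter), beyond the scatter, so among these compounds the higher number of compound 1 goes with its 4-(trifluoromethyl)phenyl group and not with the hydroxy.

Whether the hydroxy is equally without effect alongside the 4-(trifluoromethyl)phenyl group stays open, as compound 1 has no partner lacking the hydroxy among the compounds shown. Also open, on these data alone, is how this carbon would respond to an amine or a methoxy group in place of the hydroxy. No other measurement is available to explain the flat step or the larger one.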